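Aryl swap on the cinnamoyl hydrazide series: cytotoxicity outlook

The source may report more compounds than this note shows. Statements on the series, on what has been measured and on what is new or still open speak of the compounds shown alone.

Two members of the series have been measured. Compound 1 `O=C(/C=C/c1cccc(Br)c1)NNC(=O)c1ccc2c(c1)OCCO2` gives 351000 nM in an ADME assay on cells (Macrophage) for cytotoxicity, read by MTT assay, with a stated time of 24 h; a lower number here means that less compound is tolerated, a higher number that more compound is tolerated. Compound 2 `O=C(/C=C/c1cccc([N+](=O)[O-])c1)NNC(=O)c1ccc2c(c1)OCCO2` gives 323000 nM in this assay; the two values lie within the scatter of each other, so compound 2 stands level with compound 1 and neither can be set apart. Within the data shown here, the only step so far, a 1.1-fold lower number from compound 1 to compound 2 (0.04 log units; within the scatter), shows that exchanging the substituent on the aromatic ring left the number where it was.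

Compound 3 `O=C(/C=C/c1ccc(F)cc1)NNC(=O)c1ccc2c(c1)OCCO2` is the next member. (4-fluorophenyl in place of 3-nitrophenyl on a double-bonded chain carbon bound to a double-bonded chain carbon). Among the measured compounds shown here, the one step that bears on it is the bromo-to-nitro exchange, which stayed within the scatter, and nothing in the data separates one aryl substituent from another in this assay. No step beyond the scatter is therefore expected from compound 2 to compound 3, a 1.1-fold higher number from compound 2 to compound 3 (0.02 log units; within the scatter). Compound 3 is estimated at 340000 nM, with a range from 170000 nM to 680000 nM.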

Compound 3, half-maximal cytotoxic concentration: 319000 nM
Compound 3: middle estimate off by 1.1-fold (0.03 log units), on the high side; low and high end bracket the measured number.
By their numbers in this assay, from the lowest: compounds 3, 2 and 1 (each within the scatter of the next).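

In this assay, 4-fluorophenyl in place of 3-nitrophenyl gives a 1.0-fold lower number from compound 2 to compound 3 (0.01 log units; within the scatter), and 4-fluorophenyl in place of 3-bromophenyl gives a 1.1-fold lower number from compound 1 to compound 3 (0.04 log units; within the scatter). The earlier step compared only 3-substituted phenyl groups, whereas these two steps add a 4-substituted one, with a fluorine as the substituent, and the reading stays within the scatter. At this place on a double-bonded chain carbon, all three aryl groups therefore stand level, and no data are available to explain this.

The compounds shown leave open whether the level reading would hold for a phenyl group carrying an amine or a carboxylic acid. They also leave open whether a change away from this place, such as in the shared core, would move the number beyond the scatter.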